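The source may report more compounds than this note shows. Statements on the series, on what has been measured and on what is new or still open speak of the compounds shown alone.

Measured so far in an ADME assay on Vero cells (Chlorocebus sabaeus) for cytotoxicity, read by neutral red uptake, tested at 49 ug/mL; on this read-out higher numbers stand for a weaker effect at the one concentration tested and lower numbers for a stronger effect:
compound 1 `COc1ccc(C2SCC(=O)N2CCN2CCCCC2)cc1` gives 100%;
compound 2 `O=C1CSC(c2cccc(Cl)c2)N1CCN1CCCCC1` gives 100%;
compound 3 `O=C1CSC(c2cccc(O)c2)N1CCN1CCCCC1` gives 100%.

Compound 3 stands level with compounds 1 and 2 at the digits shown, all three values lying within the scatter of one another. Within the data shown here, the single step between measured compounds that differ in one place, no change at the digits printed from compound 2 to compound 3 (within the scatter), was flat. Compound 4 `O=C1CSC(c2ccc(O)cc2)N1CCN1CCCCC1` differs from compound 3 as follows: 4-hydroxyphenyl in place of 3-hydroxyphenyl on a saturated ring carbon. Among the measured compounds shown here, no measured step moves a hydroxy group around the aromatic ring, so the only bearing comes from the flat step from compound 2 to compound 3 and from the level values of compounds 1 and 2. On that basis no step beyond the scatter is expected in this assay, no change at the digits printed from compound 3 to compound 4 (within the scatter). Compound 4 is therefore estimated at 100%, within 88% to 105%.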

Compound 4, a percentage reported as activity, at one concentration (the size of the read-out at that concentration, not a potency): 96%
The estimate for compound 4 lay 4 percentage points above the measured number; the measured number falls inside the stated range.
By their numbers in this assay, from the lowest: compounds 4, 1, 2 and 3 (each within the scatter of the next).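

In this assay, 4-hydroxyphenyl in place of 3-hydroxyphenyl on the saturated ring carbon gives a number 4 percentage points lower from compound 3 to compound 4 (within the scatter) and so adds a comparison of hydroxy placement on the aromatic ring. 4-hydroxyphenyl in place of 3-chlorophenyl gives a number 4 percentage points lower from compound 2 to compound 4 (within the scatter) and hydrogen in place of methyl on the oxygen gives a number 4 percentage points lower from compound 1 to compound 4 (within the scatter) so all four aromatic groups shown stay within the scatter of one another. No available evidence bears on these small differences.

On these data alone, whether a carboxylic acid or a primary amine on the aromatic ring would produce a step beyond the scatter in this assay remains open.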